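Aniline ring swap in the pyrimidinyl urea series

The compounds below may be only part of what the source reports. "The series", "measured", "known", "first", "only" and "open" are said of these compounds alone.

Measured in a functional assay on HCC827 cells (Homo sapiens) for inhibition, read by MTT assay, with a stated time of 48 h, tested at 10 uM; a higher number here means more inhibition at the concentration tested (going by the name of the read-out), a lower number less inhibition:
compound 1 `COc1ccc(F)cc1Nc1cc(NC(=O)Nc2c(Cl)cccc2Cl)ncn1` gives 78%
compound 2 `COc1cc(NC(=O)Nc2cc(Nc3ccc(F)c(Cl)c3)ncn2)cc(OC)c1` gives 53.1%
compound 3 `COc1ccc(Nc2cc(NC(=O)Nc3c(Cl)cccc3Cl)ncn2)cc1C` gives 63.1%

Compound 2 sits below compound 1 by a gap beyond the scatter, while its gap to compound 3 is within the scatter, so compound 2 and compound 3 cannot be ordered against each other on these numbers.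

The unmeasured compound 4 `COc1cc(NC(=O)Nc2cc(Nc3cc(I)ccc3OC)ncn2)cc(OC)c1` differs from compound 2 only at the aniline ring: 5-iodo-2-methoxyphenyl in place of 3-chloro-4-fluorophenyl on a nitrogen on an aromatic ring. Going by the values given here, no measured pair shows this exact exchange. Among the compounds with values here, the one step that bears on the same position is a number 14.9 percentage points lower from compound 1 to compound 3 (beyond the scatter), a modest drop when a 2-methoxy-bearing ring gave way to a 4-methoxy-3-methylphenyl ring. Compound 1, the only compound carrying a 2-methoxy-5-halo ring at this nitrogen, is also the compound with the largest number shown, though it differs from compound 2 at two places and so gives no single step.

Taken together, a modest rise is expected on going to compound 4, of about a number 8.9 percentage points higher from compound 2 to compound 4 (within the scatter), with wide uncertainty since the pairing of the trimethoxyphenyl urea with this aniline ring is untested. Compound 4 is therefore estimated at 62%, with a range from 42% to 80%.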

Compound 4, a percentage reported as inhibition, at one concentration (the size of the read-out at that concentration, not a potency): 71%
The estimate for compound 4 lay 9 percentage points below the measured number; the measured number falls inside the stated range.
By their numbers in this assay, from the lowest: compounds 2, 3, 4 and 1 (each within the scatter of the next, the first and the last beyond it).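

In this assay, going by these compounds alone, 5-iodo-2-methoxyphenyl in place of 3-chloro-4-fluorophenyl on a nitrogen on an aromatic ring gives a number 17.9 percentage points higher from compound 2 to compound 4 (beyond the scatter), the first single-place change at this position with the rest of the molecule held as in compound 2. The earlier step, a number 14.9 percentage points lower from compound 1 to compound 3 (beyond the scatter), left a 5-fluoro-2-methoxyphenyl ring and went down, so in both pairs with a single change at this nitrogen, the compound with the 2-methoxy-5-halo ring has the higher number, a reading limited to these two pairs on two different remainders of the molecule. No measurement shown here accounts for either step.

The new step changes the halogens and the methoxy group together, so the share of each remains unresolved, and a plain 2-methoxyphenyl ring or a 5-bromo-2-methoxyphenyl ring on the same nitrogen would be needed to separate them. Also open, from the compounds shown here alone, is whether the same ring exchange gives a step of similar size with the 2,6-dichlorophenyl urea, and all these numbers are single-concentration read-outs, so potency remains undefined.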